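Ethyl in place of ethoxycarbonyl on the shared core

A few compounds are considered here, and "the series" means these few. Any claim that something is new, unique, unknown or untested is made for them only; others in the source may bear on it.

In a functional assay for inhibition, with Rattus norvegicus as the target (on this read-out higher numbers stand for weaker inhibition and lower numbers for stronger inhibition), compound 1 (`CCCCc1c(CC)c(OC)c2ccccc2c1OC(C)=O`) gives 990 nM, compound 2 (`CCCCc1c(CC)c(OC(C)=O)c2ccccc2c1OC`) gives 1130 nM and compound 3 (`CCOC(=O)c1c(CC)c(OC(C)=O)c2ccccc2c1OC`) gives 1160 nM. These three numbers lie within the scatter of one another, so compound 3 cannot be separated from either of the other two, and no order can be read among them.

The next compound is compound 4 (`CCc1c(CC)c(OC(C)=O)c2ccccc2c1OC`). The change is ethyl in place of ethoxycarbonyl on an aromatic carbon, which puts ethyl in place of ethoxycarbonyl on an aromatic carbon, ortho to a methoxy group and ortho to an ethyl group.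

For the measured compounds named here, only one measured step touches this carbon: a 1.0-fold higher number from compound 2 to compound 3 (0.01 log units; within the scatter), with ethoxycarbonyl in place of butyl. That step stays within the scatter. Going by the values given here, no compound measured so far carries ethyl at this carbon, so the evidence is thin and rests on a single exchange. On that basis, no step beyond the scatter is expected in this assay, and no direction can be assigned.

The expected step is a 1.1-fold lower number from compound 3 to compound 4 (0.02 log units; within the scatter). Compound 4 is estimated at 1100 nM, with an expected range of 600 nM to 2000 nM.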

Compound 4, half-maximal inhibitory concentration: 400 nM
For compound 4 the middle estimate is 2.8-fold (0.44 log units) above the measured one, outside the stated range (below it).
By their numbers in this assay, from the lowest: compound 4; then compounds 1, 2 and 3 (each within the scatter of the next).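

In this assay, this aromatic carbon is not indifferent to its substituent: ethyl in place of ethoxycarbonyl gives a 2.9-fold lower number from compound 3 to compound 4 (0.46 log units; beyond the scatter), and ethyl in place of butyl gives a 2.8-fold lower number from compound 2 to compound 4 (0.45 log units; beyond the scatter), although ethoxycarbonyl and butyl themselves could not be told apart, with a 1.0-fold higher number from compound 2 to compound 3 (0.01 log units; within the scatter). The same shortening of butyl to ethyl starting from compound 1, which carries the acetoxy and methoxy groups the other way round, gives a 2.5-fold lower number from compound 1 to compound 4 (0.39 log units; beyond the scatter), so the change does not depend on starting from compound 2 or compound 3. For the compounds shown here, compound 4 is thus the only one of the four compounds that separates from the others, though all three steps are modest, and nothing on hand explains the shift.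

Going by these compounds alone, with ethyl as the only short group tested at this carbon, it remains open whether the number keeps falling with a shorter substituent such as methyl, or whether propyl already behaves like ethyl or like butyl. Within the data shown here, a carboxylic acid or an amine at this carbon would show whether the trend holds beyond simple chains, and the series so far says nothing about such groups.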